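A few compounds are considered here, and "the series" means these few. Any claim that something is new, unique, unknown or untested is made for them only; others in the source may bear on it.

Measured so far:
- compound 1 `O=C(Cn1cc(CCCCO)nn1)NCc1ccccc1`: 1700 uM
- compound 2 `Nc1cccc(-c2cn(CC(=O)NCc3ccccc3)nn2)c1`: 800 uM
- compound 3 `COc1ccc(-c2cn(CC(=O)NCc3ccccc3)nn2)cc1`: "non-toxic" (no number reported)

In an ADME assay on cells (spleen, Mus musculus, strain C57BL/6) for inhibition, read by flow cytometry and propidium iodide staining, with a stated time of 24 h, at 37 degrees C (on this read-out lower numbers stand for an effect already at smaller amounts and higher numbers for an effect only at larger amounts of compound), compound 3 has no single number and is reported only as "non-toxic" (no number reported). Compound 4 `COc1cccc(-c2cn(CC(=O)NCc3ccccc3)nn2)c1` has the same atoms, joined differently: 3-methoxyphenyl in place of 4-methoxyphenyl on an aromatic carbon. This places 3-methoxyphenyl in place of 4-methoxyphenyl on an aromatic carbon. For the measured compounds named here, the only measured step, a 2.1-fold lower number from compound 1 to compound 2 (0.33 log units; beyond the scatter), is modest and concerns a different exchange, so it bears on this change only loosely. No step beyond the scatter can be firmly expected, and no direction can be given, as compound 3 offers no number to start from. The nearest guide is compound 2 at 800 uM and compound 1 at 1700 uM. For compound 4, the expected value is 1100 uM, with an estimated range of 400 uM to 3000 uM.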

Compound 4, concentration for half-maximal effect: 840 uM
Estimate against measurement, compound 4: 1.3-fold (0.12 log units) above, and the stated range covers the measured number.
By their numbers in this assay, from the lowest: compounds 2 and 4 (each within the scatter of the next); then compound 1.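

In this assay, methoxy in place of amino on an aromatic carbon gives a 1.1-fold higher number from compound 2 to compound 4 (0.02 log units; within the scatter), so these two groups are not told apart here. A second aryl group, 3-methoxyphenyl in place of 4-hydroxybutyl, gives a 2.0-fold lower number from compound 1 to compound 4 (0.31 log units; beyond the scatter), a modest lower number in the same direction as 3-aminophenyl in the earlier step. The data offer no measured explanation for these numbers. Compound 3 has no number, so the step from 4-methoxyphenyl to 3-methoxyphenyl cannot be read. On these data alone, how a carboxylic acid or a longer chain at this aromatic carbon would read remains open.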